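A few compounds are considered here, and "the series" means these few. Any claim that something is new, unique, unknown or untested is made for them only; others in the source may bear on it.

Three analogues built on one shared core have been tested in a functional assay on HCT-116 cells (Homo sapiens) for antiproliferative activity, read by MTT assay, with a stated time of 72 h; a lower number here means a stronger inhibitor, a higher number a weaker inhibitor. Compound 1 `COc1ccc(/C=C2\S/C(=N\c3ccc(C(C)(C)C)cc3)N(C)C2=O)cc1` gives > 100000 nM, which is a limit of the assay rather than a number. Compound 2 `COc1ccc(/C=C2\S/C(=N\c3ccccc3)N(C)C2=O)cc1` likewise gives > 100000 nM, again only a limit. For the measured compounds named here, compound 3 `COc1ccc(/C=C2\S/C(=N\c3ccc(Cl)cc3)N(C)C2=O)cc1` gives 10400 nM, the single real number among the three. The steps of an at least 9.6-fold lower number from compound 1 to compound 3 (0.98 log units; beyond the scatter) and an at least 9.6-fold lower number from compound 2 to compound 3 (0.98 log units; beyond the scatter) both show that chloro on that aromatic carbon goes with the stronger result. Compound 4 `COc1ccc(/C=C2\S/C(=N\c3ccc(OC)cc3)N(C)C2=O)cc1` carries methoxy in place of chloro on an aromatic carbon. Since the hydrogen and tert-butyl counterparts both sit at the limit (the limit of > 100000 nM in this assay, at which 2 of the 3 values shown sit), removing chloro is expected to cost potency, an expected step of a 5.8-fold higher number from compound 3 to compound 4 (0.76 log units; beyond the scatter). Compound 4 is therefore estimated at 60000 nM, within a range from 15000 nM to 200000 nM.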

Compound 4, half-maximal inhibitory concentration: > 100000 nM
Compound 4 gave a limit, no number; the forecaster's own chance of this, stated with the estimate: 50%; middle value at least 1.6-fold (0.22 log units) away from the limit.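

Putting methoxy in place of chloro gives an at least 9.6-fold higher number from compound 3 to compound 4 (0.98 log units; beyond the scatter), so the loss seen with hydrogen and tert-butyl at this position also extends to a group that carries an oxygen. Chloro remains the only group here with a real number, and methoxy joins the others at the limit: the limit of > 100000 nM in this assay, at which 3 of the 4 values shown sit. The steps linking compound 4 to compound 1 and compound 2 join two limits and cannot be read. As far as these compounds go, it remains open whether fluoro, bromo, a nitrile or an amine in this place would give a real number as chloro does.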